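A few compounds are considered here, and "the series" means these few. Any claim that something is new, unique, unknown or untested is made for them only; others in the source may bear on it.

Compound 2 `CCCn1c(=O)[nH]c2nc(-c3ccc(S(=O)(=O)N4CCN(Cc5cccc(Br)c5)CC4)cc3)[nH]c2c1=O` gives 0.201 nM in a functional assay on CHO cells for antagonist activity at adenosine receptor A2b (Homo sapiens), read by cAMP accumulation, with stated times of 10 min and 15 min (a lower number here means a stronger inhibitor, a higher number a weaker inhibitor), the only number shown for these compounds. Compound 1 `CCCn1c(=O)[nH]c2nc(-c3ccc(S(=O)(=O)N4CCN(c5ccc(Br)cc5)CC4)cc3)[nH]c2c1=O` gives > 0.0598 nM in this assay, which is a limit rather than a number. The step that the limit leaves unreadable from compound 1 to compound 2 is therefore of unreadable size, and the limit of > 0.0598 nM in this assay, at which 1 of the 2 values shown sits, is all that bears on it. Compound 3 `CCCn1c(=O)[nH]c2nc(-c3ccc(S(=O)(=O)N4CCN(c5cccc(F)c5)CC4)cc3)[nH]c2c1=O` differs from compound 2 by 3-fluorophenyl in place of 3-bromobenzyl on an amine nitrogen in a ring. No readable step covers this change, so the expectation for compound 3 rests on the values of compound 2 and compound 1 alone, and compound 3 is expected at 0.1 nM (range 0.03 nM to 0.4 nM), meaning an expected step of a 2.0-fold lower number from compound 2 to compound 3 (0.30 log units; within the scatter).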

Compound 3, antagonist equilibrium constant: 0.167 nM
For compound 3 the middle estimate is 1.7-fold (0.22 log units) below the measured one; low and high end bracket the measured number.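

In this assay, the swap of 3-bromobenzyl for 3-fluorophenyl on the amine nitrogen in a ring gives a 1.2-fold lower number from compound 2 to compound 3 (0.08 log units; within the scatter), so this position takes either group without a change beyond the scatter. The swap alters the halogen and the benzyl carbon together, and these two changes cannot be told apart here. The steps from compound 1 cannot be read, and all that bears on them is a limit: the limit of > 0.0598 nM in this assay, at which 1 of the 3 values shown sits.

Left open is how a 3-bromophenyl or a 3-fluorobenzyl group would read, and what an amine or a carboxylic acid on this aromatic ring would do.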